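From 2,6-dichlorophenyl to 3,4-dichlorophenyl on the carbonyl carbon

A few compounds are considered here, and "the series" means these few. Any claim that something is new, unique, unknown or untested is made for them only; others in the source may bear on it.

Compound 3 `N=C(NCCCCc1ccccc1)NC(=O)c1c(Cl)cccc1Cl` gives 5030 nM in an assay on CHO cells for inhibition of sodium channel protein type 2 subunit alpha (Homo sapiens) (a lower number here means a stronger inhibitor, a higher number a weaker inhibitor), the highest of the three numbers measured; compound 2 `N=C(NCCCCc1ccccc1)NC(=O)c1cccc(Cl)c1Cl` gives 1480 nM and compound 1 `Cc1ccc(C(=O)NC(=N)NCCCCc2ccccc2)cc1` gives 1140 nM. Both steps towards compound 3 went up beyond the scatter: a 4.4-fold higher number from compound 1 to compound 3 (0.64 log units; beyond the scatter) and a 3.4-fold higher number from compound 2 to compound 3 (0.53 log units; beyond the scatter), whereas a 1.3-fold higher number from compound 1 to compound 2 (0.11 log units; within the scatter) stayed within it. Compound 4 `N=C(NCCCCc1ccccc1)NC(=O)c1ccc(Cl)c(Cl)c1` has not yet been measured in this assay; the change from compound 3 is 3,4-dichlorophenyl in place of 2,6-dichlorophenyl on a carbonyl carbon. Going by the values given here, the 2,6-dichlorophenyl is the only group among the measured ones that carries a number beyond the scatter from its neighbours, and it sits on the high side; the 2,3-dichlorophenyl of compound 2 and the 4-methylphenyl of compound 1 lie together. Among the compounds with values here, since the 3,4-dichlorophenyl of compound 4 is a different arrangement of the same atoms as in compound 3, the two measured steps that leave the 2,6-dichlorophenyl behind are the only guide, and by them compound 4 is expected to return to the lower range, a step of a 3.6-fold lower number from compound 3 to compound 4 (0.56 log units; beyond the scatter). For compound 4 the estimate in this assay is 1400 nM, with a range from 500 nM to 4000 nM.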

Compound 4, half-maximal inhibitory concentration: 7110 nM
Compound 4: middle estimate off by 5.1-fold (0.71 log units), on the low side; the whole stated range lies below it.
By their numbers in this assay, from the lowest: compounds 1 and 2 (each within the scatter of the next); then compounds 3 and 4 (each within the scatter of the next).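

In this assay, the 3,4-dichlorophenyl on the carbonyl carbon gives no departure from the 2,6-dichlorophenyl (a 1.4-fold higher number from compound 3 to compound 4 (0.15 log units; within the scatter)), so the high number of compound 3 is no longer the mark of a single arrangement of the two chlorines. The 3,4-dichlorophenyl does stand apart from the 2,3-dichlorophenyl (a 4.8-fold higher number from compound 2 to compound 4 (0.68 log units; beyond the scatter)) and from the 4-methylphenyl (a 6.2-fold higher number from compound 1 to compound 4 (0.79 log units; beyond the scatter)), which means that a change keeping exactly the same atoms can move the number beyond the scatter in one case and leave it within the scatter in another. Among the three dichlorophenyl compounds, it is now compound 2 that stands out, lying with compound 1, so two chlorines on the ring do not by themselves set the number.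

Still open, going by these compounds, is how an unsubstituted phenyl, a single chlorine, a methoxy group or an amine on this ring would compare, and whether a longer chain on the other side of the shared core would shift these differences. Nothing available here bears on why the arrangement of the chlorines gives these numbers.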